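Shifting the halogen on the aryl ketone of compound 3

The compounds below may be only part of what the source reports. "The series", "measured", "known", "first", "only" and "open" are said of these compounds alone.

Compound 3 `O=C(/N=C1\NC2(CCCCO2)CCS1)c1ccc(Br)cc1` is measured in a functional assay on the whole organism (strain CF-1) with Mus musculus as the target, in the writhing test, with a stated time of 15 min (on this read-out lower numbers stand for an effect already at smaller amounts and higher numbers for an effect only at larger amounts of compound), only as a limit, > 200 mg/kg. Compound 1 `O=C(/N=C1\NC2(CCCCO2)CCS1)Nc1ccccc1` likewise reaches only the limit > 200 mg/kg in this assay. Compound 2 `COc1ccc(C(=O)/N=C2\NC3(CCCCO3)CCS2)cc1` gives 62 mg/kg in this assay. The change from compound 1 to compound 3 is a step that the two limits leave unreadable from compound 1 to compound 3, whereas the change from compound 2 to compound 3 is an at least 3.2-fold higher number from compound 2 to compound 3 (0.50 log units; beyond the scatter), so compound 3 sits at the weaker end of what is shown, sharing (the limit of > 200 mg/kg in this assay, at which 2 of the 3 values shown sit). Compound 4 `O=C(/N=C1\NC2(CCCCO2)CCS1)c1cccc(F)c1` differs from compound 3 by 3-fluorophenyl in place of 4-bromophenyl on a carbonyl carbon. For the measured compounds named here, no measured step exchanges one halogen for another on this ring. The step from compound 3 to compound 4 is therefore expected to be an at least 1.3-fold lower number from compound 3 to compound 4 (0.12 log units; that floor lies within the scatter), and compound 4 is estimated at 150 mg/kg, between 50 mg/kg and 400 mg/kg.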

Compound 4, dose for half-maximal effect: 9.2 mg/kg
Estimate against measurement, compound 4: 16-fold (1.21 log units) above; the measured number lies below the stated range.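

Exchanging 4-bromophenyl for 3-fluorophenyl on the carbonyl carbon brings an at least 21-fold lower number from compound 3 to compound 4 (1.33 log units; beyond the scatter) in this assay, and putting 3-fluorophenyl in place of anilino brings an at least 21-fold lower number from compound 1 to compound 4 (1.33 log units; beyond the scatter). The earlier step at this place, from the 4-methoxyphenyl of compound 2 to the 4-bromophenyl of compound 3, showed only a loss, whereas this change gives a large gain. Both new steps are floors, since each starts from a limit: the limit of > 200 mg/kg in this assay, at which 2 of the 4 values shown sit.

The step changes the halogen and its ring position together, and the compounds shown do not separate the two. They also do not tell how a chloro, methyl or trifluoromethyl group would fare in place of the fluorine.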